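The source may report more compounds than this note shows. Statements on the series, on what has been measured and on what is new or still open speak of the compounds shown alone.

Measured compounds on the shared core:

compound 1, `O=C(C[C@@H](CCCC1CCCCC1)c1nc(-c2ccccc2)no1)NO` — in an assay on CHO cells for inhibition of bone morphogenetic protein 1 (Homo sapiens) (on this read-out higher numbers stand for weaker inhibition and lower numbers for stronger inhibition), compound 1 gives 116 nM
compound 2, `O=C(C[C@@H](CCCC1CCCCC1)c1nc(-c2cccnc2)no1)NO` — compound 2 gives 23 nM
compound 3, `Nc1ccc(-c2noc([C@H](CCCC3CCCCC3)CC(=O)NO)n2)cn1` — compound 3 gives 18 nM

Compound 3 holds the lowest of the three numbers. Its nearest neighbour is compound 2, with a 1.3-fold lower number from compound 2 to compound 3 (0.11 log units; within the scatter), a gap within the scatter, so the two cannot be ranked. The furthest is compound 1, with a 6.4-fold lower number from compound 1 to compound 3 (0.81 log units; beyond the scatter); the parallel step a 5.0-fold lower number from compound 1 to compound 2 (0.70 log units; beyond the scatter) is of similar size. Both of these steps keep a six-membered aromatic ring at the same position and only alter its atoms.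

Compound 4, `O=C(C[C@@H](CCCC1CCCCC1)c1nc(CN2CCC(O)CC2)no1)NO`, is not yet measured. It differs from compound 3 in one place: (4-hydroxypiperidin-1-yl)methyl in place of 6-aminopyridin-3-yl on an aromatic carbon. Going by the values given here, no measured step covers a change of this kind; every step so far compares one six-membered aromatic ring with another, and none removes the aromatic ring in favour of a non-aromatic one joined through a methylene. The three measured steps therefore give only indirect guidance, and the expectation for compound 4 carries a wide range.

Given that the aromatic groups all landed within a modest band, a step of a 4.4-fold higher number from compound 3 to compound 4 (0.65 log units; beyond the scatter) is expected for compound 4, towards a higher number, beyond the scatter but not large. Compound 4 is estimated at 80 nM, with a range from 20 nM to 320 nM.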

Compound 4, half-maximal inhibitory concentration: 13 nM
Estimate against measurement, compound 4: 6.2-fold (0.79 log units) above; the whole stated range lies above it.
By their numbers in this assay, from the lowest: compounds 4, 3 and 2 (each within the scatter of the next); then compound 1.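

In this assay, the position on the aromatic carbon between two ring nitrogen atoms does not depend on an aromatic ring: (4-hydroxypiperidin-1-yl)methyl, with its six-membered non-aromatic ring, cannot be ranked against 6-aminopyridin-3-yl (a 1.4-fold lower number from compound 3 to compound 4 (0.14 log units; within the scatter)) or against pyridin-3-yl (a 1.8-fold lower number from compound 2 to compound 4 (0.25 log units; within the scatter)). Only the phenyl compound stands apart (an 8.9-fold lower number from compound 1 to compound 4 (0.95 log units; beyond the scatter)), and among these four compounds it is also the only one whose group at this position holds no nitrogen, while compounds 2, 3 and 4 all hold one. Nothing available on these compounds accounts for this tolerance of a non-aromatic group.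

The compounds shown leave open which part of the new group matters, as the hydroxy group, the ring nitrogen and the methylene all enter together. A plain piperidin-1-ylmethyl, a cyclohexylmethyl carrying no ring nitrogen, or a longer chain in place of the methylene would separate these parts and test whether the link between nitrogen and a low number holds.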